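Replacing 1H-indol-3-yl with 3,4-dichlorophenyl in compound 3

This account rests on a few compounds, and the source may have more. Where it says the series, first, only, none or still open, it means among the compounds named here.

Measured so far in a functional assay on DU-145 cells (Homo sapiens) for inhibition, read by trypan blue exclusion, with a stated time of 96 h; on this read-out lower numbers stand for stronger inhibition of growth and higher numbers for weaker inhibition of growth (all three values below):
- compound 1 (`COc1ccc(/C=C(\C(=O)c2ccc(Br)cc2)S(=O)(=O)Cc2ccc(Cl)cc2)cc1`) gives 25000 nM 
- compound 2 (`N#Cc1ccc(C(=O)/C(=C\c2ccc(O)c([N+](=O)[O-])c2)SCc2ccc(Br)cc2)cc1`) gives 10000 nM 
- compound 3 (`O=C(/C(=C/c1ccc(Cl)cc1)Cc1c[nH]c2ccccc12)c1ccc(Cl)cc1Cl`) gives 10000 nM 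

Compound 3 stands level with compound 2, and together they hold the lowest number of the three. Compound 1 lies above them, beyond the usual scatter of repeat measurements.

Compound 4 (`O=C(/C(=C/c1ccc(Cl)cc1)Cc1ccc(Cl)c(Cl)c1)c1ccc(Cl)cc1Cl`) differs from compound 3 in one place, with 3,4-dichlorophenyl in place of 1H-indol-3-yl on a saturated chain carbon bound to a double-bonded chain carbon.

Going by the values given here, no two measured compounds differ in just one place, so this kind of swap has no direct precedent here. Among the compounds with values here, the only anchor is compound 3 at 10000 nM (the nearest structure). In this assay the expected outcome is no change at the digits printed from compound 3 to compound 4 (within the scatter) with no shift beyond the scatter. For compound 4 the estimated value is 10000 nM within an expected range of 3500 nM to 30000 nM (an estimate, not a measurement).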

Compound 4, concentration for 50% growth inhibition: 1000 nM
The estimate for compound 4 lay 10-fold (1.00 log units) above the measured number; the measured number lies below the stated range.
By their numbers in this assay, from the lowest: compound 4; then compounds 2 and 3 (each within the scatter of the next); then compound 1.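

Going by these compounds alone, this is the first comparison in the set in which only one place changes, so it gives the first direct reading of the group on a saturated chain carbon bound to a double-bonded chain carbon in this assay. Replacing 1H-indol-3-yl with 3,4-dichlorophenyl there lowers the number (a 10-fold lower number from compound 3 to compound 4 (1.00 log units; beyond the scatter)), so growth inhibition responds to this position, and the hydrogen-bond donor of 1H-indol-3-yl is not needed for compound 4 to reach this level. No measurement here explains why the number falls.

With a single swap at this position, the compounds shown leave open whether the chlorine atoms or the removal of 1H-indol-3-yl matters more. Going by these compounds, how an unsubstituted phenyl, an amine or a carboxylic acid would behave on the same chain carbon also remains open.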